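The compounds below may be only part of what the source reports. "The series", "measured", "known", "first", "only" and "open" are said of these compounds alone.

Working notes on the series. Within the data shown here, compound 1 `CC(C)=CCC[C@@](C)(/C=C/c1ccccc1)/C=C/c1ccc(O)cc1` is the first point. In a functional assay on SEM cells (Homo sapiens) for cytotoxicity, with a stated time of 72 h (on this read-out higher numbers stand for an effect only at larger amounts of compound and lower numbers for an effect already at smaller amounts), compound 1 gives only a limit of the assay, > 36600 nM. Compound 2 `CC(C)=CCC[C@](C)(/C=C/c1ccc(O)cc1)/C=C/c1cccc(F)c1` differs from compound 1 by fluoro in place of hydrogen on an aromatic carbon. In this assay compound 2 likewise gives only a limit, > 36600 nM. The step that the two limits leave unreadable from compound 1 to compound 2 therefore cannot be read in size. Compound 3 `C=C[C@@](C)(/C=C/c1ccc(Nc2ccc(F)cc2)cc1)CCC=C(C)C` sits on another core; the difference between the two cores is not broken down here. In this assay compound 3 again gives only a limit, > 36600 nM. Compound 4 `C=C[C@@](C)(/C=C/c1ccc(Nc2ccc(F)c(F)c2)cc1)CCC=C(C)C` differs from compound 3 by fluoro in place of hydrogen on an aromatic carbon. This is the same kind of change as from compound 1 to compound 2, but here the place is ortho to a fluoro group as well as meta to a large group, whereas in compound 2 it is meta to a large group only. The step that the limit leaves unreadable from compound 3 to compound 4 is expected to be negligible, resting on (the limit of > 36600 nM in this assay, at which 3 of the 3 values shown sit). Compound 4 is estimated at 45000 nM, most likely reported again as a limit, within 20000 nM to 120000 nM.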

Compound 4, half-maximal effective concentration: > 36600 nM
Compound 4 ended at the assay's limit; the forecaster's own chance of this, stated with the estimate: 80%; the middle value lies beyond the limit too.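

Among these compounds, compound 3 and compound 4 both give only a limit in this assay, so no step between them can be read in size. The compounds shown leave open whether fluoro in place of hydrogen on an aromatic carbon changes the effect at all.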